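Changing the Aryl Group on a Calcium Channel Blocker

A few compounds are considered here, and "the series" means these few. Any claim that something is new, unique, unknown or untested is made for them only; others in the source may bear on it.

Compound 1 `COc1ccc(C2C(C(=O)O)=CNC(C(OC)OC)=C2C(=O)OC/C=C/c2ccccc2)cc1Cl`: 1500 nM
Compound 2 `O=C(O)C1=CNC=C(C(=O)OC/C=C/c2ccccc2)C1c1cccc(C(F)(F)F)c1`: 1200 nM

Of the compounds shown here, two have been measured in an assay on IMR-32 cells for inhibition of Voltage-dependent N-type calcium channel subunit alpha-1B (Homo sapiens), with a stated time of 5 min; a lower number here means a stronger inhibitor, a higher number a weaker inhibitor. Compound 1 gives 1500 nM, and compound 2 gives 1200 nM. Compound 2 has the lower of the two numbers, but the gap to compound 1 is within the scatter, so the two cannot be told apart on these data.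

Compound 3 `COc1ccc(C2C(C(=O)O)=CNC=C2C(=O)OC/C=C/c2ccccc2)cc1Cl` has not yet been measured. It differs from compound 2 in one place: 3-chloro-4-methoxyphenyl in place of 3-(trifluoromethyl)phenyl on a saturated ring carbon. For the measured compounds named here, compound 1 carries this same 3-chloro-4-methoxyphenyl group, together with a further large group on the shared core, and its number sits close to that of compound 2; that is the only guide at hand, and no step between measured compounds separates the two aryl groups on their own. The expected step from compound 2 to compound 3 is therefore a 1.1-fold higher number from compound 2 to compound 3 (0.03 log units; within the scatter), none beyond the scatter. Compound 3 is estimated at 1300 nM, with a range from 500 nM to 3500 nM.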

Compound 3, half-maximal inhibitory concentration: 1300 nM
Beside the measured number, compound 3's estimate shows no gap at the digits printed; the range from low to high includes it.
By their numbers in this assay, from the lowest: compounds 2, 3 and 1 (each within the scatter of the next).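

In this assay, the exchange of 3-(trifluoromethyl)phenyl for 3-chloro-4-methoxyphenyl on the saturated ring carbon can now be read on its own as a single step (a 1.1-fold higher number from compound 2 to compound 3 (0.03 log units; within the scatter)), so these two aryl groups cannot be told apart here, even though only the second has a hydrogen-bond acceptor. Compound 3 also isolates the large group that compound 1 carries on a double-bonded ring carbon: hydrogen in place of dimethoxymethyl gives a step that is also within the scatter (a 1.2-fold lower number from compound 1 to compound 3 (0.06 log units; within the scatter)), so the dimethoxymethyl group and a plain hydrogen cannot be told apart at that place either. Nothing at hand gives a reason for either result.

On these data alone, two aryl groups that match say little about the saturated ring carbon in general, so it remains open whether an unsubstituted phenyl, a pyridine ring or a small alkyl group there would also leave the number unchanged. As far as these compounds go, it also remains open what an amide or a methyl ester in place of the carboxy group would do.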